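A few compounds are considered here, and "the series" means these few. Any claim that something is new, unique, unknown or untested is made for them only; others in the source may bear on it.

Three compounds have numbers in a functional assay on HT-29 cells (Homo sapiens) for cytotoxicity, read by neutral red uptake, with a stated time of 72 h; on this read-out higher numbers stand for weaker inhibition and lower numbers for stronger inhibition. Compound 1, `COc1ccc(CNc2nc(NCc3ccc(OC)cc3)c3ccccc3n2)cc1`, gives 2880 nM in this assay. Compound 2, `c1ccc(CCCNc2nc(NCCCc3ccccc3)c3ccccc3n2)cc1`, gives 2200 nM in this assay. Compound 3, `CCCCNc1nc(SCC)nc2ncccc12`, gives 25300 nM in this assay, the highest of the three numbers: its nearest neighbour is compound 1, whose number is lower by an amount beyond the scatter, and compound 2 lies further still, also beyond the scatter. Compound 3 therefore stands as the weakest inhibitor among the three.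

The unmeasured compound 4, `CCCCCCNc1nc(SCC)nc2ncccc12`, shares the core of compound 3 and differs from it in one place: ethyl in place of hydrogen on a saturated chain carbon, four bonds along the chain from a nitrogen on an aromatic ring. The butyl chain on the aromatic nitrogen of compound 3 thus becomes a hexyl chain in compound 4.

Going by the values given here, no pair of measured compounds shows this kind of change, so no measured step can be carried over. On the numbers in hand, compound 1 and compound 2 carry larger groups on their aromatic nitrogens and show lower numbers than compound 3, but they differ from compound 3 in more than one place, so they give only a loose hint. A step from compound 3 to compound 4 of modest size, toward a lower number, is expected, a 1.6-fold lower number from compound 3 to compound 4 (0.20 log units; within the scatter), but one that may well remain within the scatter. Compound 4 is estimated at 16000 nM in this assay, with a range from 7000 nM to 40000 nM.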

Compound 4, half-maximal inhibitory concentration: 22500 nM
Compound 4: middle estimate off by 1.4-fold (0.15 log units), on the low side; the range from low to high includes it.
By their numbers in this assay, from the lowest: compounds 2 and 1 (each within the scatter of the next); then compounds 4 and 3 (each within the scatter of the next).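

In this assay, ethyl in place of hydrogen on a saturated chain carbon, four bonds along the chain from a nitrogen on an aromatic ring, amounts to a 1.1-fold lower number from compound 3 to compound 4 (0.05 log units; within the scatter), so the butyl and hexyl chains cannot be told apart on this read-out. This is the only step among the compounds shown that changes a single place, and it gives the first direct reading for this position: adding ethyl here produces no difference beyond the scatter. None of the information at hand explains why the number holds when the chain is extended.

Going by these compounds alone, the single step covers only the move from butyl to hexyl on the shared core, so it leaves open whether a longer chain such as octyl or decyl would also stay within the scatter. It also leaves open what a different group at the chain end, such as a hydroxyl, an amine, a carboxylic acid or a phenyl ring, would do to the number in this assay.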